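The source may hold more compounds than are shown below. What is called first, only, known or untested is meant among the compounds shown, and "the series" means these compounds.

Within the data shown here, compound 1 `Brc1ccccc1Nc1nc2cccnc2[se]1` gives 185000 nM in a functional assay on MCF7 cells (Homo sapiens) for cytotoxicity, read by MTT assay, with a stated time of 72 h (on this read-out higher numbers stand for weaker inhibition and lower numbers for stronger inhibition), the highest of the two numbers so far. Among the measured compounds shown here, compound 2 `Cc1cccc(Nc2nc3cccnc3[se]2)c1` gives 56400 nM in this assay; the two values differ beyond the scatter, but the two structures differ in more than one place, so no single step joins them. Compound 3 `Clc1ccccc1Nc1nc2cccnc2[se]1` differs from compound 1 by chloro in place of bromo on an aromatic carbon. For the measured compounds named here, no measured pair shows this exchange. The step is expected to stay within the scatter, as a 1.2-fold lower number from compound 1 to compound 3 (0.09 log units; within the scatter). Compound 3 is therefore estimated at 150000 nM, from 60000 nM to 400000 nM.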

Compound 3, half-maximal inhibitory concentration: 43300 nM
For compound 3 the middle estimate is 3.5-fold (0.54 log units) above the measured one; the whole stated range lies above it.
By their numbers in this assay, from the lowest: compounds 3 and 2 (each within the scatter of the next); then compound 1.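

Among these compounds, on an aromatic carbon ortho to a large group, the exchange of bromo for chloro is not neutral in this assay and gives a 4.3-fold lower number from compound 1 to compound 3 (0.63 log units; beyond the scatter) as the first single-place step. A change of one heavy atom at this place is therefore enough to move the number beyond the scatter, although this rests on one pair. Nothing measured bears on what lies behind this step.

Open, from the compounds shown here alone, is how fluoro, methoxy or an amine would read at this same place. Going by these compounds, it is also open whether chloro in place of bromo gives a similar step elsewhere on the ring.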